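A Methyl Group Joins the Amino Analogue

The source may hold more compounds than are shown below. What is called first, only, known or untested is meant among the compounds shown, and "the series" means these compounds.

Compound 1 `NC(=O)c1nn(C2O[C@H](CO)[C@@H](O)[C@H]2O)cc1Br`: in a functional assay on Vero cells (Chlorocebus sabaeus) (a higher number here means a weaker inhibitor, a lower number a stronger inhibitor), compound 1 gives > 1550 uM, a limit of the assay.
Compound 2 `Cc1c([N+](=O)[O-])c(C(N)=O)nn1C1O[C@H](CO)[C@@H](O)[C@H]1O`: in this assay compound 2 gives > 1650 uM, again a limit.
Compound 3 `NC(=O)c1nn(C2O[C@H](CO)[C@@H](O)[C@H]2O)cc1N`: in this assay compound 3 gives > 1830 uM, also a limit.

Compound 3 therefore stands at a limit, and the two other values shown are limits too, so no order among the three can be read. Going by the values given here, the one measured step, a step that the two limits leave unreadable from compound 1 to compound 3, rests on the limit of > 1550 uM in this assay, at which 1 of the 3 values shown sits, and the limit of > 1830 uM in this assay, at which 1 of the 3 values shown sits, and gives no size. Compound 4 `Cc1c(N)c(C(N)=O)nn1C1O[C@H](CO)[C@@H](O)[C@H]1O` differs from compound 3 by methyl in place of hydrogen on an aromatic carbon. Compound 2 already carries that methyl and sits at the limit of > 1650 uM in this assay, at which 1 of the 3 values shown sits. No change beyond the scatter is expected, so the step from compound 3 to compound 4 is estimated as a step that the limit leaves unreadable from compound 3 to compound 4. Compound 4 is expected to give about 2000 uM, within 500 uM to 6000 uM.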

Compound 4, concentration for 50% inhibition: > 1840 uM
Compound 4: only a limit was reported (the forecaster's own chance of this, stated with the estimate: 85%); the middle value is on the limit's open side.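

Compound 4 also gives only a limit, and neither its step from compound 2 nor its step from compound 3 can be read. The compounds shown leave open whether any of them inhibits at all in this assay.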